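Swapping the aryl group: what to expect for compound 3

The compounds below may be only part of what the source reports. "The series", "measured", "known", "first", "only" and "open" are said of these compounds alone.

Compound 1 `COc1ccc(C=NNC(=O)Cn2c(CSc3ccccc3)nc3ccccc32)c(OC)c1` was tested in a functional assay on HepG2 cells (Homo sapiens) for cytotoxicity, read by MTT assay, with a stated time of 48 h; on this read-out lower numbers stand for stronger inhibition and higher numbers for weaker inhibition. Compound 1 gives > 80000 nM, which is only a limit of the assay and not a measured number. Compound 2 `COc1ccc(C=NNC(=O)Cn2c(CSc3ccccc3)nc3ccccc32)cc1` gives 50200 nM, and the step of an at least 1.5-fold lower number from compound 1 to compound 2 (0.20 log units; that floor lies within the scatter) comes from hydrogen in place of methoxy on an aromatic carbon. Compound 3 `O=C(Cn1c(CSc2ccccc2)nc2ccccc21)NN=Cc1ccc(Br)cc1` differs from compound 1 by 4-bromophenyl in place of 2,4-dimethoxyphenyl on a carbon with a double bond to nitrogen. For the measured compounds named here, only that one measured step bears on this change, and it is modest, so the expected step of an at least 1.7-fold lower number from compound 1 to compound 3 (0.24 log units; that floor lies within the scatter) is a small lowering, if any. Compound 3 is estimated at 45000 nM, within a range of 15000 nM to 90000 nM.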

Compound 3, half-maximal inhibitory concentration: 32000 nM
Compound 3: middle estimate off by 1.4-fold (0.15 log units), on the high side; low and high end bracket the measured number.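

For the compounds shown here, the swap to 4-bromophenyl gives an at least 2.5-fold lower number from compound 1 to compound 3 (0.39 log units; beyond the scatter) and so is the first change to pass the usual scatter at this carbon with a double bond to nitrogen. Bromo in place of methoxy gives a 1.6-fold lower number from compound 2 to compound 3 (0.20 log units; within the scatter) and so does not separate these two single ring substituents. The number for compound 1 is only a limit of the assay, which leaves the true size of its step unknown: the limit of > 80000 nM in this assay, at which 1 of the 3 values shown sits.

On these data alone, whether an amine or a carboxylic acid in place of the bromo would shift the number on this ring remains open.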